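Carboxypiperidinyl in place of phenyl: notes on compound 4

A few compounds are considered here, and "the series" means these few. Any claim that something is new, unique, unknown or untested is made for them only; others in the source may bear on it.

Measured so far in a functional assay for agonist activity at Melanocyte-stimulating hormone receptor (Homo sapiens), read by cAMP accumulation; a lower number here means a smaller maximal response, a higher number a larger maximal response:
compound 1 `Cc1ccc(Cn2ccnc2NC(=O)[C@@H]2CN(C(C)(C)C)C[C@H]2c2ccc(F)cc2F)c(N2CCC(C(=O)O)CC2)c1` gives 101%
compound 2 `CC(C)(C)N1C[C@@H](C(=O)Nc2nccn2Cc2ccccc2)[C@H](c2ccc(F)cc2F)C1` gives 54%
compound 3 `CC(C)(C)N1C[C@@H](C(=O)Nc2nccn2Cc2ccccc2-c2ccccc2)[C@H](c2ccc(F)cc2F)C1` gives 79%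

Compound 3 stands second of the three: compound 1 lies higher and compound 2 lower, both beyond the scatter. Compound 4 `CC(C)(C)N1C[C@@H](C(=O)Nc2nccn2Cc2ccccc2N2CCC(C(=O)O)CC2)[C@H](c2ccc(F)cc2F)C1` differs from compound 3 in one place: 4-carboxypiperidin-1-yl in place of phenyl on an aromatic carbon. Among the measured compounds shown here, the one measured step at this position is a number 25 percentage points higher from compound 2 to compound 3 (beyond the scatter), an upward move of modest size. Compound 1 also carries a 4-carboxypiperidin-1-yl group and gives 101%, which points the same way. A small rise is therefore expected for compound 4, a number 16 percentage points higher from compound 3 to compound 4 (beyond the scatter), close to the edge of the scatter. Compound 4 is estimated at 95% in this assay, between 82% and 106%.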

Compound 4, intrinsic activity: the largest response reached, in percent of the reference agonist's: 104%
Compound 4: the middle estimate sits 9 percentage points below what was measured; the range from low to high includes it.
By their numbers in this assay, from the lowest: compound 2; then compound 3; then compounds 1 and 4 (each within the scatter of the next).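

In this assay, an aromatic ring is not needed at this place: 4-carboxypiperidin-1-yl in place of phenyl gives a number 25 percentage points higher from compound 3 to compound 4 (beyond the scatter), and in place of hydrogen it gives a number 50 percentage points higher from compound 2 to compound 4 (beyond the scatter). With this group present, the methyl of compound 1 makes no readable difference, as hydrogen in its place gives a number 3 percentage points higher from compound 1 to compound 4 (within the scatter). No available measurement accounts for these steps. On these data alone, it remains open whether the response depends on the carboxylic acid or on the piperidine ring, which a plain piperidin-1-yl or a methyl ester at the same aromatic carbon would help separate.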